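The compounds below may be only part of what the source reports. "The series", "measured", "known", "first", "only" and "open" are said of these compounds alone.

Measured so far in a functional assay on NCI-H460 cells (Homo sapiens) for cytotoxicity, read by MTT assay, with a stated time of 72 h; a higher number here means a weaker inhibitor, a lower number a stronger inhibitor:
Compound 1 `CC(C)(C)c1[nH]cnc1/C=c1\[nH]c(=O)/c(=C/c2cccc(Oc3ccc(F)cc3)c2)[nH]c1=O` gives 4 nM
Compound 2 `CC(C)c1[nH]cnc1/C=c1\[nH]c(=O)/c(=C/c2cccc(Oc3ccc(F)cc3)c2)[nH]c1=O` gives 8.8 nM
Compound 3 `O=c1[nH]/c(=C\c2ccccn2)c(=O)[nH]/c1=C\c1cccc(Oc2ccc(F)cc2)c1` gives 49.1 nM

Compound 3 has the highest number of the three and is the weakest of them, with compound 2 its nearest neighbour. Compound 4 `O=c1[nH]/c(=C\c2cccc(Oc3ccc(F)cc3)c2)c(=O)[nH]/c1=C\c1ccccc1` has not yet been measured. It differs from compound 3 by one exchange, (phenyl in place of pyridin-2-yl on a double-bonded chain carbon bound to an aromatic carbon), with phenyl in place of pyridin-2-yl on a double-bonded chain carbon bound to an aromatic carbon. Among the measured compounds shown here, no measured step makes this exchange. The nearest evidence comes from the same place, where pyridin-2-yl replaced 5-isopropyl-1H-imidazol-4-yl, with a 5.6-fold higher number from compound 2 to compound 3 (0.75 log units; beyond the scatter), and 5-(tert-butyl)-1H-imidazol-4-yl, with a 12-fold higher number from compound 1 to compound 3 (1.09 log units; beyond the scatter). Neither step shows how phenyl compares with pyridin-2-yl. The change elsewhere, a 2.2-fold higher number from compound 1 to compound 2 (0.34 log units; beyond the scatter), bears on it even less. Little movement is therefore expected in this assay, and no direction can be favoured with confidence. The estimated step is a 1.1-fold lower number from compound 3 to compound 4 (0.04 log units; within the scatter). For compound 4 the expected value is 45 nM, with an estimated range from 14 nM to 140 nM.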

Compound 4, half-maximal inhibitory concentration: 389 nM
Beside the measured number, compound 4's estimate is 8.6-fold (0.94 log units) below it, and the stated range ends below it.
By their numbers in this assay, from the lowest: compound 1; then compound 2; then compound 3; then compound 4.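

In this assay, this position responds strongly to a change of one ring atom: phenyl and pyridin-2-yl have the same count of heavy atoms and differ in the ring nitrogen, yet the exchange gives a clear loss (a 7.9-fold higher number from compound 3 to compound 4 (0.90 log units; beyond the scatter)). The steps from the two imidazole compounds are larger (a 44-fold higher number from compound 2 to compound 4 (1.65 log units; beyond the scatter); a 97-fold higher number from compound 1 to compound 4 (1.99 log units; beyond the scatter)), so among these four compounds, all three groups with ring nitrogen give lower numbers than the carbon-only ring, and none goes against this order. Nothing measured here explains why phenyl does so much worse.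

The compounds shown leave open how a piperidine, or a phenyl bearing an amine or a carboxylic acid, would compare on this double-bonded chain carbon. They also do not show whether phenyl would give the same loss with a different group on the other side of the shared core.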